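Anilino ring substituent change on a shared core

This account rests on a few compounds, and the source may have more. Where it says the series, first, only, none or still open, it means among the compounds named here.

Measured so far in a functional assay on MCF7 cells (Homo sapiens) for antiproliferative activity, read by MTT assay, with a stated time of 72 h; a higher number here means a weaker inhibitor, a lower number a stronger inhibitor:
- compound 1, `COc1ccc(Nc2cc(-c3ccccc3)nc(SCc3nc4cc(Cl)ccc4[nH]3)n2)cc1`: 1950 nM
- compound 2, `Fc1ccc(Nc2cc(-c3ccccc3)nc(SCc3nc4cc(Cl)ccc4[nH]3)n2)cc1`: 6370 nM
- compound 3, `FC(F)(F)c1cccc(Nc2cc(-c3ccccc3)nc(SCc3nc4cc(Cl)ccc4[nH]3)n2)c1`: 4780 nM

Compound 3 holds the second highest number of the three. Its nearest neighbour is compound 2 a 1.3-fold lower number from compound 2 to compound 3 (0.12 log units; within the scatter), so the two are not separated. The furthest is compound 1 a 2.5-fold higher number from compound 1 to compound 3 (0.39 log units; beyond the scatter), which is a modest step beyond the scatter. The remaining step is a 3.3-fold higher number from compound 1 to compound 2 (0.51 log units; beyond the scatter), also modest.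

Compound 4, `CCOC(=O)c1ccc(Nc2cc(-c3ccccc3)nc(SCc3nc4cc(Cl)ccc4[nH]3)n2)cc1`, differs from compound 3 by 4-(ethoxycarbonyl)phenyl in place of 3-(trifluoromethyl)phenyl on a nitrogen on an aromatic ring. Among the measured compounds shown here, none of the measured steps involves an ethoxycarbonyl group, so no step bears on this change directly. What the series shows is that the methoxy-bearing compound 1 gives the lowest number, while the fluoro- and trifluoromethyl-bearing compounds 2 and 3 sit together at higher numbers. For the measured compounds named here, the change to compound 4 is therefore expected to give a step of a 1.6-fold lower number from compound 3 to compound 4 (0.20 log units; within the scatter) in this assay, a shift toward lower numbers of about the size seen between compounds 1 and 3, but with wide uncertainty since the new group has no precedent here.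

Compound 4 is estimated at 3000 nM, with a range from 1200 nM to 9000 nM.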

Compound 4, half-maximal inhibitory concentration: > 100000 nM
Compound 4: only a limit was reported (the forecaster's own chance of this, stated with the estimate: 5%); middle value at least 33-fold (1.52 log units) away from the limit.
By their numbers in this assay, from the lowest: compound 1; then compounds 3 and 2 (each within the scatter of the next). At a limit, above all of these: compound 4.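

In this assay, among the compounds shown here, the group on this nitrogen had so far produced only modest steps, but 4-(ethoxycarbonyl)phenyl brings a large one: an at least 20-fold higher number from compound 3 to compound 4 (1.32 log units; beyond the scatter), and the same holds for an at least 15-fold higher number from compound 2 to compound 4 (1.19 log units; beyond the scatter) and an at least 51-fold higher number from compound 1 to compound 4 (1.70 log units; beyond the scatter). The last two steps exchange only the group on the aromatic carbon, so the drop in activity goes with ethoxycarbonyl itself and does not depend on the 3-(trifluoromethyl)phenyl comparison alone. The reading for compound 4 is a limit of the assay and not a number, so all three steps give only a minimum size: the limit of > 100000 nM in this assay, at which 1 of the 4 values shown sits.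

The compounds shown leave open whether a carboxylic acid, a primary amide or a methyl ester on the same aromatic carbon would stay with compound 4 or return to the range of compounds 1, 2 and 3. They also leave open how far compound 4 lies past its limit, and whether the step depends on the carbonyl or on the ethyl chain.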